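Sulfonamides on a Shared Core That Stay at the Limit

A few compounds are considered here, and "the series" means these few. Any claim that something is new, unique, unknown or untested is made for them only; others in the source may bear on it.

Three sulfonamides built on one shared core were examined in an assay on isolated protein for inhibition of malate dehydrogenase, mitochondrial (Sus scrofa), with stated times of 45 min and 30 min; on this read-out lower numbers stand for stronger inhibition and higher numbers for weaker inhibition. Compound 1 `O=S(=O)(Nc1ccc2oc(-c3ccccc3)nc2c1)c1cccc(C(F)(F)F)c1` returns only a limit of the assay, > 63000 nM. Compound 2 `O=S(=O)(Nc1ccc2oc(-c3ccccc3)nc2c1)c1ccc(Cl)c(C(F)(F)F)c1` likewise returns only a limit, > 63000 nM. Compound 3 `O=S(=O)(Nc1ccc2oc(-c3ccccc3)nc2c1)c1cccc(Cl)c1` also returns only a limit, > 63000 nM. The step from compound 1 to compound 2, chloro in place of hydrogen on an aromatic carbon, is a step that the two limits leave unreadable from compound 1 to compound 2, and the step from compound 1 to compound 3, chloro in place of trifluoromethyl on an aromatic carbon, is a step that the two limits leave unreadable from compound 1 to compound 3. Compound 3 therefore stands where every measured compound stands: at the limit of > 63000 nM in this assay, at which 3 of the 3 values shown sit. Compound 4 `CCc1ccc(S(=O)(=O)Nc2ccc3oc(-c4ccccc4)nc3c2)cc1` differs from compound 3 by 4-ethylphenyl in place of 3-chlorophenyl on a sulfonyl sulfur. Since no measured step is readable in size, nothing shown supports a change in this assay beyond the scatter, and the three limits point toward compound 4 again sitting at the limit. Compound 4 is accordingly expected to give 100000 nM in this assay, within a range from 20000 nM to 500000 nM. The step from compound 3 to compound 4 that this estimate implies is a step that the limit leaves unreadable from compound 3 to compound 4.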

Compound 4, half-maximal inhibitory concentration: > 63000 nM
Compound 4: a limit, no number (the forecaster's own chance of this, stated with the estimate: 85%); the middle value lies beyond the limit too.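

Compound 4 gives only a limit (> 63000 nM), and the step between compound 3 and compound 4 cannot be read in size. The four compounds stand together: (the limit of > 63000 nM in this assay, at which 4 of the 4 values shown sit). The compounds shown leave open whether any change on the shared core can bring a readable value in this assay at all.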